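An Amide in Place of the Acid at the Core

This account rests on a few compounds, and the source may have more. Where it says the series, first, only, none or still open, it means among the compounds named here.

Compound 1, `O=C(O)CSc1ccc(NCc2cccc(Oc3ccccc3)c2)cc1`: 324 nM
Compound 2, `CC(Cc1ccc(NCc2cccc(Oc3ccccc3)c2)cc1)C(=O)O`: 100 nM
Compound 3, `O=C(O)[C@@H]1C[C@H]1c1ccc(NCc2cccc(Oc3ccccc3)c2)cc1`: 562 nM

All three share the core of compound 1 and were tested in a functional assay on CHO cells for agonist activity at Free fatty acid receptor 1 (Homo sapiens); a higher number here means that more compound is needed for the effect, a lower number that less compound is needed. Compound 3 and compound 1 lie within the scatter of each other (a 1.7-fold higher number from compound 1 to compound 3 (0.24 log units; within the scatter)), and compound 3 stands apart from compound 2 (a 5.6-fold higher number from compound 2 to compound 3 (0.75 log units; beyond the scatter)). Compound 4, `CC(C)NC(=O)CCc1ccc(NCc2cccc(Oc3ccccc3)c2)cc1`, differs from compound 3 by 2-(isopropylcarbamoyl)ethyl in place of 2-carboxycyclopropyl on an aromatic carbon. Every measured step, a 3.2-fold lower number from compound 1 to compound 2 (0.51 log units; beyond the scatter) included, swaps one carboxy-bearing group for another, whereas compound 4 carries no carboxy at all, so those steps bear on it only loosely. A shift to a clearly higher number is therefore expected, a 6.2-fold higher number from compound 3 to compound 4 (0.79 log units; beyond the scatter). Compound 4 is estimated at 3500 nM, with a range from 800 nM to 15000 nM.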

Compound 4, half-maximal effective concentration: 39.8 nM
For compound 4 the middle estimate is 88-fold (1.94 log units) above the measured one; measured number below the stated range.
By their numbers in this assay, from the lowest: compound 4; then compound 2; then compounds 1 and 3 (each within the scatter of the next).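

On an aromatic carbon para to a large group, a carboxy turns out not to be needed in this assay: 2-(isopropylcarbamoyl)ethyl has none, yet it gives the largest step here (a 14-fold lower number from compound 3 to compound 4 (1.15 log units; beyond the scatter)) and also improves on the thioether acid (an 8.1-fold lower number from compound 1 to compound 4 (0.91 log units; beyond the scatter)). Even against 1-carboxyethyl on the saturated chain carbon bound to an aromatic carbon, (isopropylcarbamoyl)methyl gives a smaller step that is still beyond the scatter (a 2.5-fold lower number from compound 2 to compound 4 (0.40 log units; beyond the scatter)). Nothing available accounts for this gain. The compounds shown leave open how 2-carboxyethyl, the plain acid on the same chain, would compare with compound 4. They also leave open whether a smaller amide, 2-(methylcarbamoyl)ethyl, would hold the effect.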